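The source may hold more compounds than are shown below. What is called first, only, known or untested is meant among the compounds shown, and "the series" means these compounds.

Compound 1 `COc1cc2c(Nc3nc4ccc(C(=O)Nc5c(C)cc(C)cc5C)cc4s3)ncnc2cc1OCCCN1CCC(C)CC1` gives 7700 nM in a functional assay on NCI-H661 cells (Homo sapiens) for cytotoxicity, read by WST assay, with a stated time of 72 h; on this read-out higher numbers stand for weaker inhibition and lower numbers for stronger inhibition.
Compound 2 `COc1cc2c(Nc3nc4ccc(C(=O)Nc5c(C)cc(C)cc5C)cc4s3)ncnc2cc1OCCCN1CCCCC1C` gives 8800 nM in this assay.
Compound 3 `CCN(CC)CCCOc1cc2ncnc(Nc3nc4ccc(C(=O)Nc5c(C)cccc5Cl)cc4s3)c2cc1OC` gives 11200 nM in this assay.

Compound 3 has the highest number of the three, but the gaps to compound 2 and to compound 1 are both within the usual scatter, so nothing separates these three compounds on the numbers shown. Within the data shown here, the one measured step, a 1.1-fold higher number from compound 1 to compound 2 (0.06 log units; within the scatter), concerns the amine end of the side chain and also stays within the scatter.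

Compound 4 `CCN(CC)CCCOc1cc2ncnc(Nc3nc4ccc(C(=O)Nc5c(C)cc(C)cc5C)cc4s3)c2cc1OC` differs from compound 3 at the amide: 2,4,6-trimethylphenyl in place of 2-chloro-6-methylphenyl on an amide-type nitrogen. Among the measured compounds shown here, no measured step touches this amide-bearing group, since compound 1 and compound 2 carry the 2,4,6-trimethylphenyl while changing the chain instead, and compound 3 alone carries the 2-chloro-6-methylphenyl. What is known is that all three measured compounds, with either aryl group, sit close together. The step of a 1.2-fold lower number from compound 3 to compound 4 (0.09 log units; within the scatter) is therefore expected to stay within the scatter. Compound 4 is estimated at 9000 nM in this assay, with a range from 4000 nM to 20000 nM.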

Compound 4, half-maximal inhibitory concentration: 7300 nM
Estimate against measurement, compound 4: 1.2-fold (0.09 log units) above; measured number inside the range.
By their numbers in this assay, from the lowest: compounds 4, 1, 2 and 3 (each within the scatter of the next).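

In this assay, the amide-type nitrogen now has its first measured step, 2,4,6-trimethylphenyl in place of 2-chloro-6-methylphenyl (a 1.5-fold lower number from compound 3 to compound 4 (0.19 log units; within the scatter)). The amine end of the chain also gains two comparisons, diethylamino in place of 2-methylpiperidin-1-yl (a 1.2-fold lower number from compound 2 to compound 4 (0.08 log units; within the scatter)) and diethylamino in place of 4-methylpiperidin-1-yl (a 1.1-fold lower number from compound 1 to compound 4 (0.02 log units; within the scatter)). Neither position therefore shows a step beyond the scatter among these four compounds, whichever of these groups it carries.

No measurement shown here bears on why these steps are so small. Still open, from the compounds shown here alone, is whether a plain unsubstituted phenyl or a pyridine ring on the amide nitrogen, or a morpholine at the chain end, would give a step beyond the scatter.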